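Replacing a small chain group with thiophen-3-yl

The compounds below may be only part of what the source reports. "The series", "measured", "known", "first", "only" and "open" are said of these compounds alone.

In a functional assay for inhibition, with Homo sapiens as the target (on this read-out higher numbers stand for weaker inhibition and lower numbers for stronger inhibition), compound 1 (`CC(C)OC(=O)C(Cc1cccc(OCC(=O)O)c1)c1nc(-c2ccccc2)c(-c2ccccc2)o1`) gives 1220 nM, while compound 2 (`C[S+]([O-])C(Cc1cccc(OCC(=O)O)c1)c1nc(-c2ccccc2)c(-c2ccccc2)o1`) gives 7080 nM, the higher of the two numbers. Compound 3 (`O=C(O)COc1cccc(CC(c2ccsc2)c2nc(-c3ccccc3)c(-c3ccccc3)o2)c1`) alters compound 2 in one place: a group of 5 heavy atoms (4 carbon, 1 sulfur; one five-membered aromatic ring with 1 hetero atom) in place of a group of 3 heavy atoms (1 carbon, 1 oxygen, 1 sulfur; no ring), on a saturated chain carbon bound to an aromatic carbon and a saturated chain carbon. Going by the values given here, the only measured change on this carbon is a 5.8-fold higher number from compound 1 to compound 2 (0.76 log units; beyond the scatter), a modest step beyond the scatter, and there the larger group went with the lower number. One pair is thin evidence, but a modest step to a lower number is expected, a 3.9-fold lower number from compound 2 to compound 3 (0.59 log units; beyond the scatter). For compound 3 the estimated value is 1800 nM, within an expected range of 400 nM to 7000 nM.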

Compound 3, half-maximal inhibitory concentration: 20700 nM
Estimate against measurement, compound 3: 12-fold (1.06 log units) below; measured number outside the range, above it.
By their numbers in this assay, from the lowest: compound 1; then compound 2; then compound 3.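

In this assay thiophen-3-yl on this saturated chain carbon gives a 2.9-fold higher number from compound 2 to compound 3 (0.47 log units; beyond the scatter) and a 17-fold higher number from compound 1 to compound 3 (1.23 log units; beyond the scatter) here, so this ring does not bring the lower number that the larger group brought before. Size alone does not set the order: thiophen-3-yl is larger than the group it replaces in compound 2 yet inhibits more weakly, while compound 1, with the largest group, inhibits most strongly. Nothing shown gives a reason for this order.

From the compounds shown here alone, whether an amine or a methyl ester on this carbon would match compound 1 stays open.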